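Removing one methoxy group from compound 2

This account rests on a few compounds, and the source may have more. Where it says the series, first, only, none or still open, it means among the compounds named here.

Measured compounds:
compound 1 `COc1ccc(-c2cc(/C=C/C(=O)c3ccc(N)cc3)[nH]n2)cc1`: -63%
compound 2 `COc1cc(-c2cc(/C=C/C(=O)c3ccc(N)cc3)[nH]n2)cc(OC)c1OC`: -86%
compound 3 `COc1cc(-c2cc(/C=C/C(=O)c3ccc(F)c(F)c3)[nH]n2)cc(OC)c1OC`: -61%

In a functional assay on RXF 393 cells (Homo sapiens) for cytotoxicity, read by sulforhodamine B assay, with a stated time of 48 h, tested at 100 uM (a higher number here means a weaker effect of the compound at the concentration tested, a lower number a stronger effect), compound 2 gives the lowest of the three numbers; compound 1 and compound 3 both read higher, beyond the scatter. Compound 4 `COc1ccc(-c2cc(/C=C/C(=O)c3ccc(N)cc3)[nH]n2)cc1OC` differs from compound 2 by hydrogen in place of methoxy on an aromatic carbon. For the measured compounds named here, the only single-point step known, a number 25 percentage points higher from compound 2 to compound 3 (beyond the scatter), changes the group on the carbonyl carbon and so does not bear on a change in the methoxy pattern. Going by the values given here, the only guide is compound 1, which carries one methoxy group and reads -63%, against -86% for compound 2; compound 4, with two methoxy groups, is expected to land between them. Compound 4 is therefore estimated at -75% (range -92% to -58%), a step of a number 11 percentage points higher from compound 2 to compound 4 (beyond the scatter).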

Compound 4, a percentage reported as activity, at one concentration (the size of the read-out at that concentration, not a potency): -95%
Beside the measured number, compound 4's estimate is 20 percentage points above it; measured number below the stated range.
By their numbers in this assay, from the lowest: compounds 4 and 2 (each within the scatter of the next); then compounds 1 and 3 (each within the scatter of the next).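

In this assay, the methoxy on the aromatic carbon ortho to a methoxy group and meta to a large group can be replaced by hydrogen with no readable loss, with a number 9 percentage points lower from compound 2 to compound 4 (within the scatter) as the step. Adding a methoxy to the one-methoxy ring counts for far more, with a number 32 percentage points lower from compound 1 to compound 4 (beyond the scatter) as the step, so the second methoxy carries the readable difference and the third does not.

From the compounds shown here alone, whether a hydroxyl or an ethoxy group at this place reads like methoxy or like hydrogen remains open. Nothing at hand explains either step.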